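This account rests on a few compounds, and the source may have more. Where it says the series, first, only, none or still open, it means among the compounds named here.

Three measured compounds, all in a functional assay on A549 cells (Homo sapiens) for cytotoxicity, read by crystal violet staining, with a stated time of 3 days; on this read-out lower numbers stand for stronger inhibition and higher numbers for weaker inhibition:

Compound 1 `COc1cc2c(cc1OC)C(/C(C)=N/NC(N)=S)N(S(=O)(=O)c1ccc([N+](=O)[O-])cc1)CC2` gives > 50 ug/mL, a limit of the assay rather than a number.
Compound 2 `COc1ccc(S(=O)(=O)N2CCc3cc(OC)c(OC)cc3C2/C(C)=N/NC(N)=S)cc1` gives > 50 ug/mL, again a limit.
Compound 3 `C/C(=N\NC(N)=S)C1c2ccccc2CCN1S(=O)(=O)c1ccc(C)cc1` gives > 50 ug/mL, also a limit.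

Compound 1 and compound 2 differ by a methoxy in place of nitro on an aromatic carbon; with both values being limits, the step from compound 1 to compound 2 is a step that the two limits leave unreadable from compound 1 to compound 2. Compound 3 stands where the whole set stands: the limit of > 50 ug/mL in this assay, at which 3 of the 3 values shown sit, so nothing separates it from compound 1 or compound 2 in this assay.

Compound 4 `C/C(=N\NC(N)=S)C1c2ccccc2CCN1S(=O)(=O)c1cccc([N+](=O)[O-])c1` differs from compound 3 by 3-nitrophenyl in place of 4-methylphenyl on a sulfonyl sulfur. Within the data shown here, no measured step bears readably on this change, and no direction can be drawn from the measured compounds. The step expected for a step that the limit leaves unreadable from compound 3 to compound 4 is therefore no readable step at all, with the strong likelihood that compound 4 also returns only a limit. Compound 4 is estimated at 60 ug/mL, within a range from 15 ug/mL to 250 ug/mL.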

Compound 4, half-maximal inhibitory concentration: > 50 ug/mL
Compound 4: no number, only a limit; the forecaster's own chance of this, stated with the estimate: 80%; the middle value lies beyond the limit too.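

No step from compound 3 to compound 4 can be read, since both values are limits in this assay: the limit of > 50 ug/mL in this assay, at which 4 of the 4 values shown sit.

The compounds shown leave open whether 3-nitrophenyl or 4-methylphenyl on the sulfonyl sulfur matters to this read-out at all, and what actual value any of them would give.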